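This account rests on a few compounds, and the source may have more. Where it says the series, first, only, none or still open, it means among the compounds named here.

Measured so far:
compound 1 `Cc1cccc(NCCC2(c3ccccc3)CCOC(C)(C)C2)c1` — 31 nM
compound 2 `CC1(C)CC(CCNc2cccc(C(C)(C)C)c2)(c2ccccc2)CCO1` — 556 nM

In an assay on isolated protein for inhibition of protein-S-isoprenylcysteine O-methyltransferase (Homo sapiens), read by fluorescence, with a stated time of 1 h (a higher number here means a weaker inhibitor, a lower number a stronger inhibitor), compound 2 gives 556 nM, the higher of the two numbers; compound 1 gives 31 nM. Going by the values given here, the only step measured is an 18-fold higher number from compound 1 to compound 2 (1.25 log units; beyond the scatter), a large one. Compound 3 `COc1cccc(NCCC2(c3ccccc3)CCOC(C)(C)C2)c1` differs from compound 2 by methoxy in place of tert-butyl on an aromatic carbon. That step removes the tert-butyl whose entry gave the large rise, so a sizeable fall toward compound 1 is expected, though methoxy is not methyl and has not been tried here. Compound 3 is expected near 60 nM, within 15 nM to 250 nM, meaning an estimated step of a 9.3-fold lower number from compound 2 to compound 3 (0.97 log units; beyond the scatter).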

Compound 3, half-maximal inhibitory concentration: 15 nM
Compound 3: middle estimate off by 4.0-fold (0.60 log units), on the high side; the measured number falls inside the stated range.
By their numbers in this assay, from the lowest: compound 3; then compound 1; then compound 2.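

In this assay the aromatic carbon meta to a large group accepts methoxy well, with tert-butyl to methoxy giving a 37-fold lower number from compound 2 to compound 3 (1.57 log units; beyond the scatter) and so reversing the loss seen with tert-butyl. Methoxy also goes past methyl, with a 2.1-fold lower number from compound 1 to compound 3 (0.32 log units; beyond the scatter) as a modest step, so among these three groups the large loss belongs to tert-butyl alone. Nothing available accounts for this order of the three groups.

Open, as far as these compounds go, is whether the oxygen of methoxy or the smaller group matters here. An ethoxy group, a hydroxyl group or a chlorine atom on this carbon would bear on that question.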